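This account rests on a few compounds, and the source may have more. Where it says the series, first, only, none or still open, it means among the compounds named here.

In a functional assay on HL-60 cells (Homo sapiens) for inhibition, read by MTT assay, with a stated time of 72 h (a higher number here means a weaker inhibitor, a lower number a stronger inhibitor), compound 2 `Cc1nc(-c2cccc(F)c2)c(C(=O)N2CCN(c3cccc(Cl)c3)CC2)o1` gives 33.7 nM and compound 3 `COc1cc(OC)cc(N2CCN(C(=O)c3oc(C)nc3-c3cccc(F)c3)CC2)c1` gives 28.2 nM so the two stand together among the numbers available. Among the measured compounds shown here, the one measured step of a 1.2-fold lower number from compound 2 to compound 3 (0.08 log units; within the scatter) is 3,5-dimethoxyphenyl in place of 3-chlorophenyl on an amine nitrogen in a ring. For the measured compounds named here, compound 1 `COc1cccc(N2CCN(C(=O)c3oc(C(F)(F)F)nc3-c3cccc(F)c3)CC2)c1` is reported as "not active" (no number reported) without a number and so supplies no step.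

Compound 4 `COc1cccc(N2CCN(C(=O)c3oc(C)nc3-c3cccc(F)c3)CC2)c1` takes compound 3 from 3,5-dimethoxyphenyl to 3-methoxyphenyl, with hydrogen in place of methoxy on an aromatic carbon. Going by the values given here, no measured step removes a methoxy group, so the evidence is indirect. Among the compounds with values here, the only guide is the change on that same aromatic ring, a 1.2-fold lower number from compound 2 to compound 3 (0.08 log units; within the scatter) and on that basis no step beyond the scatter is expected in this assay and no direction can be given. The estimated step is a 1.1-fold higher number from compound 3 to compound 4 (0.03 log units; within the scatter) and it carries no firm direction. Compound 4 is expected at 30 nM with an estimated range from 12 nM to 80 nM in repeat measurements.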

Compound 4, half-maximal inhibitory concentration: "not active" (no number reported)
Nothing numeric was reported for compound 4, and the estimate cannot be compared.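

In this assay, among the compounds shown here, compound 4 gives "not active" (no number reported) and so no step from compound 3 can be read. No measured property bears on this result. The compounds shown leave open how far compound 4 lies from compound 3, and whether 3,5-dimethoxyphenyl to 3-methoxyphenyl alone accounts for the missing number.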